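The source may report more compounds than this note shows. Statements on the series, on what has been measured and on what is new or still open speak of the compounds shown alone.

In an assay on isolated protein for displacement of a labelled ligand from metabotropic glutamate receptor 5 (Homo sapiens), with a stated time of 60 min, tested at 1 uM (a lower number here means less inhibition, a higher number more inhibition at the concentration tested (going by the name of the read-out)), the three measured compounds give the following numbers.

Compound 1 `CC1CCN(c2c(S(=O)(=O)c3cc(Cl)cc(Cl)c3)cnc3c(F)cccc23)CC1` gives 82%.
Compound 2 `CC1CCN(c2c(S(=O)(=O)c3ccc(F)c(F)c3)cnc3c(F)cccc23)CC1` gives 93%.
Compound 3 `CC1CCN(c2c(S(=O)(=O)c3ccc(C#N)cc3)cnc3c(F)cccc23)CC1` gives 86%.

Compound 3 sits second of these three numbers, but the step of a number 4 percentage points higher from compound 1 to compound 3 (within the scatter) and the step of a number 7 percentage points lower from compound 2 to compound 3 (within the scatter) both fall within the usual scatter of repeated measurements, so no order between compound 3 and either neighbour can be read from them. For the measured compounds named here, only the step of a number 11 percentage points higher from compound 1 to compound 2 (beyond the scatter) reaches beyond the scatter, and even that one is modest.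

Compound 4 `Cc1ccc(S(=O)(=O)c2cnc3c(F)cccc3c2N2CCC(C)CC2)cc1` has not yet been measured. It differs from compound 3 in a single place: methyl in place of cyano on an aromatic carbon. All three measured steps bear on this change. Each of them also swaps the group sitting on the aromatic ring attached to the sulfonyl sulfur while the shared core stays untouched. Two of those steps lie within the scatter and the third is modest, so the step of a number 1 percentage points lower from compound 3 to compound 4 (within the scatter) is expected to stay within the scatter, in no clear direction. Compound 4 is therefore estimated at 85% in this assay, with a range from 70% to 95%.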

Compound 4, a percentage reported as inhibition, at one concentration (the size of the read-out at that concentration, not a potency): 93%
For compound 4 the middle estimate is 8 percentage points below the measured one; the range from low to high includes it.
By their numbers in this assay, from the lowest: compounds 1, 3, 2 and 4 (each within the scatter of the next, the first and the last beyond it).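

In this assay, putting methyl in place of cyano on this aromatic carbon, para to a large group, gives a number 7 percentage points higher from compound 3 to compound 4 (within the scatter) and so no readable change: at this position, the group with one hydrogen-bond acceptor and a triple bond can give way to one with neither, and the inhibition holds up. The 4-methylphenyl group also shows no change at the digits printed from compound 2 to compound 4 (within the scatter) against 3,4-difluorophenyl, which leaves those two groups level in this assay. Against 3,5-dichlorophenyl it shows a number 11 percentage points higher from compound 1 to compound 4 (beyond the scatter) and so joins 3,4-difluorophenyl as a second group with a modest lead over that ring, while nothing at hand gives a reason for any of these numbers.

The aromatic rings shown carry only cyano, methyl, fluorine or chlorine, so it remains open whether an amine, a carboxylic acid or a longer chain on the same carbon would keep the inhibition. From the compounds shown here alone, each number in this assay is also the size of the read-out at one concentration and not a potency, so how far these compounds differ in potency remains unknown.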